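Adding an amino group to the phenyl of compound 3

This account rests on a few compounds, and the source may have more. Where it says the series, first, only, none or still open, it means among the compounds named here.

Measured in a functional assay on the whole organism with Mus musculus as the target; a higher number here means that more compound is needed for the effect, a lower number that less compound is needed:
Compound 1 `COc1cc2c(cc1OC)C(c1ccc([N+](=O)[O-])cc1)=NN=C(S)C2`: 69.8 umol/kg
Compound 2 `COc1cc2c(cc1OC)C(c1ccc(Br)cc1)=NN=C(S)C2`: 33.3 umol/kg
Compound 3 `COc1cc2c(cc1OC)C(c1ccccc1)=NN(C)C(=S)C2`: 24.7 umol/kg

In this assay compound 3 gives 24.7 umol/kg, which lies within the scatter of compound 2 at 33.3 umol/kg. The number for compound 3 is lower than that of compound 1, 69.8 umol/kg, and this gap lies beyond the scatter.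

The next compound, compound 4 `COc1cc2c(cc1OC)C(c1ccc(N)cc1)=NN(C)C(=S)C2`, keeps the core of compound 3 and changes the phenyl to 4-aminophenyl: amino in place of hydrogen on an aromatic carbon. This places amino in place of hydrogen on an aromatic carbon, para to a large group.

Among the compounds with values here, only one measured step offers any guide. It is a 2.1-fold lower number from compound 1 to compound 2 (0.32 log units; beyond the scatter), a modest step that puts bromo in place of nitro on an aromatic carbon, on a core that differs from that of compound 3. Within the data shown here, no measured pair shows what amino does, or what any group does when it replaces hydrogen, so the direction remains open. By that one measure a modest step is expected, and a lower number is only a tentative lean.

The expected change is a 1.8-fold lower number from compound 3 to compound 4 (0.25 log units; within the scatter). For compound 4 the estimate is 14 umol/kg, with an expected range from 5 umol/kg to 38 umol/kg.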

Compound 4, dose for half-maximal effect: 20.3 umol/kg
Compound 4: middle estimate off by 1.5-fold (0.16 log units), on the low side, and the stated range covers the measured number.
By their numbers in this assay, from the lowest: compounds 4, 3 and 2 (each within the scatter of the next); then compound 1.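

In this assay, placing amino in place of hydrogen on an aromatic carbon, para to a large group, gives a 1.2-fold lower number from compound 3 to compound 4 (0.09 log units; within the scatter), so the two numbers cannot be told apart. This pair gives the first measured replacement of a hydrogen among the compounds shown and the first step on the core of compound 3; the earlier step, a 2.1-fold lower number from compound 1 to compound 2 (0.32 log units; beyond the scatter), exchanged one group for another on a different core. At this position, then, adding amino to the phenyl of compound 3 brings no change beyond the scatter, and nothing available explains this result.

From the compounds shown here alone, it remains open whether this holds only for amino or for the position as a whole, since a single group says little about how other groups would behave there, such as a carboxylic acid, a methoxy group, or the bromo and nitro groups of compound 2 and compound 1 placed on the core of compound 3. Going by these compounds, whether a larger group on the nitrogen of the amine, such as an acetyl or a longer chain, would keep the number within the scatter also remains open.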